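Swapping trifluoromethyl for fluoro on a xanthine-like scaffold

The source may hold more compounds than are shown below. What is called first, only, known or untested is meant among the compounds shown, and "the series" means these compounds.

Measured so far:
- compound 1, `CC(C)Cn1c(=O)c2nc(-c3cnn(Cc4cccc(C(F)(F)F)c4)c3)[nH]c2n(CC(C)C)c1=O`: 3100 nM
- compound 2, `CCCn1c(=O)c2nc(-c3cnn(Cc4c(F)cccc4F)c3)[nH]c2n(CCC)c1=O`: "not determined" (no result reported)

In an assay on CHO cells for displacement of a labelled ligand from adenosine receptor A1 (Homo sapiens) (on this read-out lower numbers stand for stronger inhibition and higher numbers for weaker inhibition), compound 1 gives 3100 nM. Among the compounds with values here, this is the only number in the set, so compound 1 cannot be placed as stronger or weaker than anything else; compound 2 carries a different core decoration, and in this assay compound 2 gives "not determined" (no result reported), which offers nothing to compare against.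

Compound 3, `CC(C)Cn1c(=O)c2nc(-c3cnn(Cc4cccc(F)c4)c3)[nH]c2n(CC(C)C)c1=O`, has not been measured. It differs from compound 1 in one spot: fluoro in place of trifluoromethyl on an aromatic carbon. Both groups carry no hydrogen-bond donors or acceptors and no charge, so the change is small in what is counted, although a group of four heavy atoms becomes one of one.

Within the data shown here, no pair of measured compounds shows what such a swap does here, so there is no step to lean on. The expectation is that compound 3 stays close to compound 1 in this assay, with a 1.1-fold higher number from compound 1 to compound 3 (0.05 log units; within the scatter) judged as no clear step beyond the scatter in either direction. Compound 3 is therefore estimated at 3500 nM, within 1200 nM to 10000 nM.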

Compound 3, inhibition constant: 830 nM
The estimate for compound 3 lay 4.2-fold (0.62 log units) above the measured number; measured number outside the range, below it.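

In this assay, replacing 3-(trifluoromethyl)benzyl with 3-fluorobenzyl gives a 3.7-fold lower number from compound 1 to compound 3 (0.57 log units; beyond the scatter), so the substituent on this aromatic carbon, meta to a large group, does affect the read-out, and the change goes beyond the usual scatter of repeated measurements. Compound 3, with the single fluorine atom, is the stronger inhibitor of this pair, which shows that the trifluoromethyl group of compound 1, with its four heavy atoms, is not needed for binding to this receptor in this series; this rests on one modest step between two compounds, so it is not yet a pattern. Nothing measured here accounts for the direction or size of the step.

As far as these compounds go, whether the number would keep falling with plain hydrogen at this spot, or would move with a chlorine atom or a methoxy group there, stays open, as does the effect of moving the fluorine to another carbon of the ring. Within the data shown here, compound 2 offers no number, so no step involving it can be read, and it remains unknown whether the same swap would give a similar step with other chains on the shared core, such as propyl.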